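Dropping One Trifluoromethyl Group: Compound 1 to Compound 4

The compounds below may be only part of what the source reports. "The series", "measured", "known", "first", "only" and "open" are said of these compounds alone.

compound 1 `O=C(Nc1cccc(-n2cc(-c3ccncc3)c(-c3ccc(Cl)c(O)c3)n2)c1)Nc1cc(C(F)(F)F)cc(C(F)(F)F)c1` — 5270 nM
compound 2 `COc1cc(-c2nn(-c3cccc(NC(=O)Nc4ccc(Cl)c(C(F)(F)F)c4)c3)cc2-c2ccncc2)ccc1Cl` — 15600 nM
compound 3 `COc1cc(-c2nn(-c3cccc(NC(=O)c4ccccc4)c3)cc2-c2ccncc2)ccc1Cl` — > 100000 nM (a limit of the assay)

In a functional assay on ACHN cells (Homo sapiens) for inhibition, read by sulforhodamine B assay, with a stated time of 48 h (on this read-out higher numbers stand for weaker inhibition of growth and lower numbers for stronger inhibition of growth), compound 1 gives 5270 nM, the lowest of the two numbers shown. Compound 2 gives 15600 nM, a higher number, and the gap between the two lies beyond the usual scatter. Compound 3 gives only a limit of the assay, > 100000 nM, and no number. Among the compounds with values here, the single one-place step measured so far runs an at least 6.4-fold higher number from compound 2 to compound 3 (0.80 log units; beyond the scatter); it is known only as a floor, because compound 3 sits at the limit of > 100000 nM in this assay, at which 1 of the 3 values shown sits.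

Compound 4 `O=C(Nc1cccc(-n2cc(-c3ccncc3)c(-c3ccc(Cl)c(O)c3)n2)c1)Nc1cccc(C(F)(F)F)c1` differs from compound 1 in one place: hydrogen in place of trifluoromethyl on an aromatic carbon. Within the data shown here, no measured step touches a trifluoromethyl group; the only measured step changes the group on the carbonyl carbon and says nothing direct about this substituent. Compound 2, which carries a single trifluoromethyl on that ring alongside a chlorine and differs from compound 1 elsewhere as well, gives the higher of the two numbers. A modest weakening of growth inhibition is therefore expected, in the direction of a higher number, with little confidence in its size. The expected step is a 2.1-fold higher number from compound 1 to compound 4 (0.32 log units; beyond the scatter). Compound 4 is estimated at 11000 nM, within a range of 4000 nM to 35000 nM.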

Compound 4, concentration for total growth inhibition: > 32500 nM
Compound 4 gave a limit, no number (the forecaster's own chance of this, stated with the estimate: 10%); middle value at least 2.9-fold (0.47 log units) from the limit.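

Within the data shown here, this step is the first measured change at a trifluoromethyl group, since the only earlier step concerned the group on the carbonyl carbon. In this assay, replacing one trifluoromethyl with hydrogen on the aromatic carbon, meta to a trifluoromethyl group that stays in place, gives an at least 6.1-fold higher number from compound 1 to compound 4 (0.79 log units; beyond the scatter) and so shows that growth inhibition depends on this position, even with the rest of the molecule unchanged. Compound 4 gives only a limit of the assay, > 32500 nM in this read-out, and the step is known only as a floor because of where that value sits: the limit of > 32500 nM in this assay, at which 1 of the 4 values shown sits.

The compounds shown do not reveal how much of the loss comes from the absence of this particular group, since hydrogen is the only replacement at this position and no measured value shows whether a nitrile, a methyl group or an amine on the same aromatic carbon would keep the number close to that of compound 1. They also leave open whether the same change would have a similar effect on the methoxy-bearing core of compound 2.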